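Swapping the Ester Alkyl Group on a Cell-Growth Inhibitor

The source may report more compounds than this note shows. Statements on the series, on what has been measured and on what is new or still open speak of the compounds shown alone.

Measured compounds:
compound 1 `C=CS(=O)(=O)NC/C=C/c1cc(OC)cc(O)c1C(=O)OC(C)C`: 16.6%
compound 2 `C=CS(=O)(=O)NC/C=C/c1cc(OC)cc(O)c1C(=O)OCC(C)c1ccccc1`: 9.5%
compound 3 `COc1cc(O)c(C(=O)OCC(C)c2ccccc2)c(/C=C/CN2C(=O)C=CC2=O)c1`: 56%

All three were tested in a functional assay on HL-60 cells (Homo sapiens) for inhibition, read by luminescence, with a stated time of 72 h, tested at 5 uM; a lower number here means less inhibition of growth, a higher number more inhibition of growth at the concentration tested. Compound 3 gives the highest number, and its steps to compound 1 and compound 2 are both beyond the scatter. Compound 2 and compound 3 differ in their core: a group of 7 heavy atoms (4 carbon, 1 nitrogen, 2 oxygen; one five-membered non-aromatic ring with 1 hetero atom) in place of a group of 6 heavy atoms (2 carbon, 1 nitrogen, 2 oxygen, 1 sulfur; no ring), on a saturated chain carbon bound to a double-bonded chain carbon. That step is a number 46.5 percentage points higher from compound 2 to compound 3 (beyond the scatter). Compound 1 and compound 2 share the core of compound 2 and differ only by isopropyl in place of 2-phenylpropyl on an oxygen next to a carbonyl group; that step is a number 7.1 percentage points higher from compound 2 to compound 1 (within the scatter), so the two are within the scatter of each other.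

Compound 4 `COc1cc(O)c(C(=O)OC(C)C)c(/C=C/CN2C(=O)C=CC2=O)c1` has not yet been measured. It carries the core of compound 3 and differs from it by isopropyl in place of 2-phenylpropyl on an oxygen next to a carbonyl group, the same change as from compound 2 to compound 1, at the same place. Because the earlier step was a number 7.1 percentage points higher from compound 2 to compound 1 (within the scatter), the step from compound 3 to compound 4 is expected to be small, about a number 4 percentage points higher from compound 3 to compound 4 (within the scatter). Compound 4 is therefore estimated at 60% in this assay, with a likely range from 42% to 78%. This expectation rests on a single prior example of the change.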

Compound 4, percent growth inhibition at one concentration: 65.7%
The estimate for compound 4 lay 5.7 percentage points below the measured number; the range from low to high includes it.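

In this assay, isopropyl in place of 2-phenylpropyl gives a number 9.7 percentage points higher from compound 3 to compound 4 (within the scatter), and this change reads the same on both cores: the same change on two cores in this assay, a number 7.1 percentage points higher (within the scatter) from compound 2 to compound 1 and a number 9.7 percentage points higher (within the scatter) from compound 3 to compound 4, 2.6 percentage points apart, within the scatter of two such steps The five-membered ring group in place of the sulfur-containing open chain gives a number 49.1 percentage points higher from compound 1 to compound 4 (beyond the scatter), and this large step also carries over between the two esters: the same change on two cores in this assay, a number 46.5 percentage points higher (beyond the scatter) from compound 2 to compound 3 and a number 49.1 percentage points higher (beyond the scatter) from compound 1 to compound 4, 2.6 percentage points apart, within the scatter of two such steps Together, these results show that, for these four compounds, each change has about the same effect whichever form the other part of the molecule takes, but two pairs at a single concentration cannot show that this would hold on other cores or for other changes.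

The compounds shown leave open whether the ester position tolerates more than these two alkyl groups, for example a longer straight chain such as n-butyl or a free carboxylic acid in place of the ester. They also leave open how an amine would compare with the two groups on the saturated chain carbon.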